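Replacing 3,4-difluorophenyl with pyridin-4-yl on the carbonyl carbon

A few compounds are considered here, and "the series" means these few. Any claim that something is new, unique, unknown or untested is made for them only; others in the source may bear on it.

Of the compounds shown here, three on the shared core have been measured in a functional assay on A2780 cells (Homo sapiens) for antiproliferative activity, read by fluorescence, with a stated time of 72 h (on this read-out higher numbers stand for weaker inhibition and lower numbers for stronger inhibition), and they differ only in the group on a carbonyl carbon. Compound 1 `CN1CCC(C(=O)N2Cc3c(NC(=O)C4CCC4)n[nH]c3C2(C)C)CC1`, with cyclobutyl, gives 140 nM. Compound 2 `CN1CCC(C(=O)N2Cc3c(NC(=O)c4ccc5ccccc5c4)n[nH]c3C2(C)C)CC1`, with naphthalen-2-yl, gives 270 nM. Compound 3 `CN1CCC(C(=O)N2Cc3c(NC(=O)c4ccc(F)c(F)c4)n[nH]c3C2(C)C)CC1`, with 3,4-difluorophenyl, gives 100 nM.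

Two steps fix the place of compound 3. One is a 1.4-fold lower number from compound 1 to compound 3 (0.15 log units; within the scatter), which leaves it level with compound 1. The other is a 2.7-fold lower number from compound 2 to compound 3 (0.43 log units; beyond the scatter), which sets it apart from compound 2.

Compound 4 `CN1CCC(C(=O)N2Cc3c(NC(=O)c4ccncc4)n[nH]c3C2(C)C)CC1` carries pyridin-4-yl in place of 3,4-difluorophenyl on a carbonyl carbon. All three measured steps bear on this change, since they fall at the same place. Besides the two above there is a 1.9-fold higher number from compound 1 to compound 2 (0.29 log units; within the scatter). Quite different groups have thus moved the number little, and the largest step, the one reaching compound 3 from compound 2, is only modest. For the measured compounds named here, no compound with a hetero atom in this ring has been measured, so the direction is uncertain, and a small drift upward is assumed.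

The expected step for compound 4 is a 1.5-fold higher number from compound 3 to compound 4 (0.18 log units; within the scatter), which would not clearly exceed the scatter. Compound 4 is estimated at 150 nM, with an expected range from 60 nM to 380 nM.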

Compound 4, half-maximal inhibitory concentration: 500 nM
The estimate for compound 4 lay 3.3-fold (0.52 log units) below the measured number; measured number above the stated range.
By their numbers in this assay, from the lowest: compounds 3, 1, 2 and 4 (each within the scatter of the next, the first and the last beyond it).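

In this assay, for the compounds shown here, the group on this carbonyl carbon proves able to move the number more than the earlier compounds showed: pyridin-4-yl in place of 3,4-difluorophenyl gives a 5.0-fold higher number from compound 3 to compound 4 (0.70 log units; beyond the scatter), the largest step at this position so far. The change also separates compound 4 from the cyclobutyl compound (a 3.6-fold higher number from compound 1 to compound 4 (0.55 log units; beyond the scatter)), whereas the comparison with the naphthalen-2-yl compound (a 1.9-fold higher number from compound 2 to compound 4 (0.27 log units; within the scatter)) leaves those two level, so the shift is not shared equally across the earlier groups and cannot be read simply as a ranking of aromatic against non-aromatic rings. Nothing available here accounts for why this one ring, the only one with a hetero atom, behaves as it does.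

The single change removes both fluorines and brings in the ring nitrogen, so the compounds shown cannot say which of the two carries the step, and a plain phenyl group on the same carbonyl carbon would divide them. Nor do they tell whether the place of the nitrogen in the ring counts, which pyridin-3-yl or pyridin-2-yl would address.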